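Series notes: imidazolyl replacement on the oxazolidinone side chain

The source may report more compounds than this note shows. Statements on the series, on what has been measured and on what is new or still open speak of the compounds shown alone.

For the measured compounds named here, compound 2 `COC(=O)CC1CCN(C[C@H]2CN(c3ccc(-n4cc(-c5ccccn5)cn4)c(F)c3)C(=O)O2)CC1` gives 1.78 in a physicochemical assay for lipophilicity, read by HPLC, measured as octanol-water partition (a higher number here means a more lipophilic compound, a lower number a more polar compound), the lowest of the three numbers so far. Compound 3 `CC(=O)OC[C@H]1CN(c2ccc(-n3cc(-c4ccccn4)cn3)c(F)c2)C(=O)O1` gives 2.09 and compound 1 `CCN1CCN(C[C@H]2CN(c3ccc(-n4cc(-c5ccccn5)cn4)c(F)c3)C(=O)O2)CC1` gives 2.19; the gap from compound 2 to each lies beyond the scatter, as seen in a number 0.31 log units higher from compound 2 to compound 3 (beyond the scatter) and a number 0.41 log units lower from compound 1 to compound 2 (beyond the scatter), whereas a number 0.10 log units lower from compound 1 to compound 3 (within the scatter) stays within it.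

Compound 4 `O=C1O[C@@H](Cn2ccnc2)CN1c1ccc(-n2cc(-c3ccccn3)cn2)c(F)c1` differs from compound 2 as follows: 1H-imidazol-1-yl in place of 4-((methoxycarbonyl)methyl)piperidin-1-yl on a saturated chain carbon bound to a saturated ring carbon. Going by the values given here, only the steps from compound 2 bear on this change, and they show that exchanging the 4-((methoxycarbonyl)methyl)piperidin-1-yl group for a smaller group shifts this assay by a modest amount upward at most. Among the compounds with values here, no measured step introduces an aromatic ring at this place, so the direction is taken from compound 3 and treated as uncertain. A step of about a number 0.07 log units higher from compound 2 to compound 4 (within the scatter) is therefore expected, which would lie within the scatter. Compound 4 is estimated at 1.85, with a range from 1.45 to 2.25.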

Compound 4, partition coefficient: 1.73
Compound 4: middle estimate off by 0.12 log units, on the high side; the measured number falls inside the stated range.
By their numbers in this assay, from the lowest: compounds 4 and 2 (each within the scatter of the next); then compounds 3 and 1 (each within the scatter of the next).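

In this assay, the 1H-imidazol-1-yl group and the 4-((methoxycarbonyl)methyl)piperidin-1-yl group cannot be told apart on this saturated chain carbon, with a number 0.05 log units lower from compound 2 to compound 4 (within the scatter), although one brings a five-membered aromatic ring and the other a six-membered non-aromatic ring carrying an ester. The same aromatic ring separates from the other two groups, with a number 0.36 log units lower from compound 3 to compound 4 (beyond the scatter) and a number 0.46 log units lower from compound 1 to compound 4 (beyond the scatter), so compound 4 joins compound 2 in a low pair, while compound 3 and compound 1 form a high pair. Nothing available accounts for this grouping.

The compounds shown leave open whether a phenyl ring or a triazole ring at this place would read with the imidazole. They also leave open how a carboxylic acid in place of the methyl ester of compound 2 would read.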